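The source may hold more compounds than are shown below. What is called first, only, known or untested is meant among the compounds shown, and "the series" means these compounds.

Measured so far:
compound 1, `COc1cc(-c2cc(/C=C/C(=O)c3ccc(Cl)c(Cl)c3)[nH]n2)cc(OC)c1OC`: 105%
compound 2, `COc1ccc(-c2cc(/C=C/C(=O)c3cc(OC)c(OC)c(OC)c3)[nH]n2)cc1OC`: 86%

In a functional assay on MCF7 cells (Homo sapiens) for cytotoxicity, read by sulforhodamine B assay, with a stated time of 48 h, tested at 0.1 uM (on this read-out lower numbers stand for a stronger effect and higher numbers for a weaker effect at the one concentration tested), compound 1 gives 105%, the higher of the two numbers; compound 2 gives 86%, a gap beyond the usual scatter. Compound 3, `COc1cc(-c2cc(/C=C/C(=O)c3ccc(F)c(F)c3)[nH]n2)cc(OC)c1OC`, is not yet measured. Against compound 1 it differs in one place: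
3,4-difluorophenyl in place of 3,4-dichlorophenyl on a carbonyl carbon
Going by the values given here, no measured pair of this kind is available, so the size of this step is unknown. Little change beyond the scatter is expected, in either direction, given that compound 1 already gives 105%. Compound 3 is estimated at 100%, within a range from 85% to 115%. The step of a number 5 percentage points lower from compound 1 to compound 3 (within the scatter) is expected to stay within the scatter.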

Compound 3, a percentage reported as activity, at one concentration (the size of the read-out at that concentration, not a potency): 98%
For compound 3 the middle estimate is 2 percentage points above the measured one; the range from low to high includes it.
By their numbers in this assay, from the lowest: compound 2; then compounds 3 and 1 (each within the scatter of the next).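

In this assay, 3,4-difluorophenyl in place of 3,4-dichlorophenyl on a carbonyl carbon gives a number 7 percentage points lower from compound 1 to compound 3 (within the scatter). At this position, then, the exchange of chlorine for fluorine leaves the read-out unchanged at the one concentration tested. No supporting measurement bears on this result.

As far as these compounds go, whether a phenyl ring carrying an amine or a carboxylic acid at this place would move the read-out remains open. Also open, from the compounds shown here alone, is how compound 1 and compound 3 behave at other concentrations.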